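The compounds below may be only part of what the source reports. "The series", "measured", "known", "first", "only" and "open" are said of these compounds alone.

Compound 2 `Fc1ccc(C2=CC3CNCC(C2)C3)cn1` carries a fluoro substituent on the aromatic ring and, in an in vitro functional assay on SH-SY5Y cells for agonist activity at Neuronal acetylcholine receptor; alpha3/beta4 (Homo sapiens), read by FLIPR and calcium flux (on this read-out lower numbers stand for an effect already at smaller amounts and higher numbers for an effect only at larger amounts of compound), compound 2 gives 99 nM. Of the three measured compounds it shows the highest number. Compound 3 `C1=C(c2cccnc2)C[C@@H]2CNC[C@H]1C2` lacks any halogen on that ring and gives 73 nM, a number within the scatter of that of compound 2. Among the compounds with values here, compound 1 `Clc1ccc(C2=CC3CNCC(C2)C3)cn1`, the chloro analogue, gives 16 nM, and the one-place step a 6.2-fold higher number from compound 1 to compound 2 (0.79 log units; beyond the scatter) is the only measured step in this set.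

Compound 4 `CN1CC2C=C(c3ccc(F)nc3)CC(C2)C1` differs from compound 2 by methyl in place of hydrogen on an amine nitrogen in a ring. Within the data shown here, no measured step touches the amine nitrogen in a ring; the only step on record concerns the halogen on the aromatic carbon, so it does not bear on this change. With nothing to go on beyond the starting value of compound 2, a small shift toward a higher number is expected, a 2.0-fold higher number from compound 2 to compound 4 (0.31 log units; beyond the scatter), but with wide uncertainty. For compound 4 the expected value is therefore 200 nM, with a range from 50 nM to 900 nM.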

Compound 4, half-maximal effective concentration: > 10000 nM
Compound 4: a limit, no number; the forecaster's own chance of this, stated with the estimate: 10%; middle value at least 50-fold (1.69 log units) away from the limit.
By their numbers in this assay, from the lowest: compound 1; then compounds 3 and 2 (each within the scatter of the next). At a limit, above all of these: compound 4.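

In this assay compound 4 gives > 10000 nM, which is a limit of the assay and not a number. Within the data shown here, the amine nitrogen in a ring thus proves to be a place where one added carbon matters greatly: methyl in place of hydrogen there gives an at least 100-fold higher number from compound 2 to compound 4 (2.00 log units; beyond the scatter), whereas the only earlier step, on the halogen at the aromatic carbon, was a 6.2-fold higher number from compound 1 to compound 2 (0.79 log units; beyond the scatter). The true size of the new step stays unknown, since one end of it rests on a limit: the limit of > 10000 nM in this assay, at which 1 of the 4 values shown sits.

Going by these compounds, whether an ethyl group, a longer chain or an acetyl group on that nitrogen would behave like methyl remains open. On these data alone, the methyl is seen here only with the fluoro substituent, so its effect alongside the chloro substituent of compound 1 or the unsubstituted ring of compound 3 also remains open.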